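The source may report more compounds than this note shows. Statements on the series, on what has been measured and on what is new or still open speak of the compounds shown alone.

Of the compounds shown here, three from one series have been tested in an ADME assay on HELF cells (Homo sapiens) for cytotoxicity, with a stated time of 3 days; on this read-out higher numbers stand for lower toxicity in this test and lower numbers for higher toxicity in this test. Compound 1, `CC(C)C[C@H](NC(=O)[C@]1(Cc2ccccc2)CCN1C(=O)OCc1ccccc1)C(N)=O`, gives 100000 nM. Compound 2, `C[C@H](NC(=O)[C@@]1(Cc2ccccc2)CCN1C(=O)OCc1ccccc1)C(=O)NC(C)(C)C`, does not give a number in this test but only a limit, reported as > 100000 nM. Compound 3, `C[C@H](NC(=O)[C@]1(Cc2ccccc2)CCN1C(=O)Oc1cccc2ccccc12)C(N)=O`, likewise stops at a limit, > 100000 nM. Compound 2 therefore stands where nothing more than a limit is known for it, and it shares that position with one other compound; the point in question is the limit of > 100000 nM in this assay, at which 2 of the 3 values shown sit. The measured value of compound 1 sits close to that same point.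

Compound 4, `C[C@H](NC(=O)[C@@]1(Cc2ccccc2)CCN1C(=O)OCc1ccccc1)C(=O)N(C)C`, has not yet been measured. It differs from compound 2 in one place: dimethylamino in place of (tert-butyl)amino on a carbonyl carbon. For the measured compounds named here, no step between two measured compounds is available, so nothing here shows how a change of this kind moves the read-out. Compound 2 is known only as a limit, and the expectation for compound 4 is that it stays in the same region: the step of a number no higher from compound 2 to compound 4 (the limit leaves the size open) is expected to be no change beyond the scatter of the test. Compound 4 is accordingly estimated at 100000 nM, with a range from 50000 nM to 200000 nM, and the test may well again report only a limit.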

Compound 4, minimum cytotoxic concentration: > 100000 nM
Compound 4 gave a limit, no number (the forecaster's own chance of this, stated with the estimate: 70%); the middle value lies on the limit itself.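

Compound 2 and compound 4 each give only a limit in this assay, so no step can be read between them: the limit of > 100000 nM in this assay, at which 3 of the 4 values shown sit.

The compounds shown leave open whether dimethylamino in place of (tert-butyl)amino on a carbonyl carbon changes the read-out at all, and in which direction.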